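A 4-butylpiperazin-1-yl group gives way to piperidin-1-yl

The source may hold more compounds than are shown below. What is called first, only, known or untested is meant among the compounds shown, and "the series" means these compounds.

Measured in a functional assay on HCT-116 cells (Homo sapiens) for cytotoxicity, read by MTT assay, with a stated time of 72 h; a lower number here means a stronger inhibitor, a higher number a weaker inhibitor:
- compound 1 `CN(C)CCCCCn1c2c(c3ccccc31)C(=O)c1c[n+]([O-])c3ccccc3c1C2=O`, 470 nM
- compound 2 `O=C1c2c[n+]([O-])c3ccccc3c2C(=O)c2c1c1ccccc1n2CCCCn1ccnc1`, 240 nM
- compound 3 `CCCCN1CCN(CCCCn2c3c(c4ccccc42)C(=O)c2c[n+]([O-])c4ccccc4c2C3=O)CC1`, 1920 nM

Compound 3 has the highest number of the three, at 1920 nM, and is the weakest inhibitor here. The next structure, compound 4 `O=C1c2c[n+]([O-])c3ccccc3c2C(=O)c2c1c1ccccc1n2CCCCN1CCCCC1`, differs from it as follows: piperidin-1-yl in place of 4-butylpiperazin-1-yl on a saturated chain carbon, four bonds along the chain from an aromatic nitrogen. In words, piperidin-1-yl stands in place of 4-butylpiperazin-1-yl on a saturated chain carbon, four bonds along the chain from an aromatic nitrogen.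

Within the data shown here, no measured compound carries piperidin-1-yl, so the evidence is indirect. Two steps introduce 4-butylpiperazin-1-yl at this place: a 4.1-fold higher number from compound 1 to compound 3 (0.61 log units; beyond the scatter) and an 8.0-fold higher number from compound 2 to compound 3 (0.90 log units; beyond the scatter). Both are modest but beyond the scatter. The step between the other two groups, a 2.0-fold lower number from compound 1 to compound 2 (0.29 log units; within the scatter), stays within it. Removing 4-butylpiperazin-1-yl is therefore expected to lower the number by a similarly modest amount. The step expected for compound 4 is a 3.7-fold lower number from compound 3 to compound 4 (0.57 log units; beyond the scatter). The estimated value for compound 4 is 520 nM, with an expected range of 190 nM to 1400 nM.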

Compound 4, half-maximal inhibitory concentration: 200 nM
Compound 4: the middle estimate sits 2.6-fold (0.41 log units) above what was measured; low and high end bracket the measured number.
By their numbers in this assay, from the lowest: compounds 4, 2 and 1 (each within the scatter of the next, the first and the last beyond it); then compound 3.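

In this assay, piperidin-1-yl on this saturated chain carbon gives a 9.6-fold lower number from compound 3 to compound 4 (0.98 log units; beyond the scatter), so a six-membered non-aromatic ring at this place does not by itself carry the weakness of compound 3. The group also holds up against the two smaller groups, with a 1.2-fold lower number from compound 2 to compound 4 (0.08 log units; within the scatter) and a 2.4-fold lower number from compound 1 to compound 4 (0.37 log units; beyond the scatter), which leaves compound 3 as the only one of the four that stands apart as weaker. No separate measurement bears on the reason for this result.

The change removes the butyl group and a ring nitrogen together, so the compounds shown cannot say which of the two matters; an unsubstituted piperazin-1-yl or a 4-methylpiperazin-1-yl group would separate them. Going by these compounds, whether piperidin-1-yl behaves the same way on a shorter or longer chain also remains open.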